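Swapping the amide partner in a bradykinin receptor antagonist series

The source may hold more compounds than are shown below. What is called first, only, known or untested is meant among the compounds shown, and "the series" means these compounds.

Compound 2 `Cc1cc(S(=O)(=O)N2C=CNC(=O)[C@H]2CC(=O)N[C@H]2CCNCC2(C)C)c(C)cc1Cl` is one of two compounds with numbers in an in vitro functional assay on cells for antagonist activity at B1 bradykinin receptor (Homo sapiens), read by luminescence and calcium flux, with a stated time of 2 h; a higher number here means a weaker inhibitor, a lower number a stronger inhibitor. In this assay compound 2 gives 0.31 nM, the lowest of the two numbers; compound 1 `CC1(C)CNCC[C@@H]1NC(=O)C[C@@H]1C(=O)NC=CN1S(=O)(=O)c1ccc(Cl)c(Cl)c1` gives 0.65 nM, and the difference is a 2.1-fold lower number from compound 1 to compound 2 (0.32 log units; beyond the scatter), a change of the aryl group on the sulfonyl sulfur. Compound 3 `Cc1cc(S(=O)(=O)N2C=CNC(=O)[C@H]2CC(=O)N2CC[C@H](N3CCCC3)C2)c(C)cc1Cl` differs from compound 2 elsewhere: a group of 10 heavy atoms (8 carbon, 2 nitrogen; 2 five-membered non-aromatic rings with 1 hetero atom each) in place of a group of 9 heavy atoms (7 carbon, 2 nitrogen; one six-membered non-aromatic ring with 1 hetero atom), on a carbonyl carbon. For the measured compounds named here, no measured step touches this part of the molecule, so the only step seen, from compound 1 to compound 2, does not bear on the change at the carbonyl carbon. The loss of both hydrogen-bond donors and the new ring pair leave the direction open. Compound 3 is therefore estimated at 1.5 nM in this assay, in the range 0.3 nM to 8 nM, which corresponds to an expected step of a 4.8-fold higher number from compound 2 to compound 3 (0.68 log units; beyond the scatter) with wide uncertainty.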

Compound 3, half-maximal inhibitory concentration: 19 nM
Estimate against measurement, compound 3: 13-fold (1.10 log units) below; measured number outside the range, above it.
By their numbers in this assay, from the lowest: compound 2; then compound 1; then compound 3.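

In this assay the group on the carbonyl carbon counts for far more than the aryl group on the sulfonyl sulfur: this change gives a 61-fold higher number from compound 2 to compound 3 (1.79 log units; beyond the scatter), against only a 2.1-fold lower number from compound 1 to compound 2 (0.32 log units; beyond the scatter) for the aryl change. The group with one six-membered non-aromatic ring and 2 hydrogen-bond donors therefore cannot be swapped freely for the group with 2 five-membered non-aromatic rings and 0 hydrogen-bond donors. No measurement offered here explains the size of this loss.

Ring size, ring number and donor count all change together in this one step, so the compounds shown cannot separate their contributions. As far as these compounds go, it also stays open whether an open-chain amine on the carbonyl carbon, such as a dimethylaminoethyl amide, would give a number closer to that of compound 2 or compound 3.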